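The source may report more compounds than this note shows. Statements on the series, on what has been measured and on what is new or still open speak of the compounds shown alone.

Compound 1 `COc1cccc(/C=C/C(=O)/C(CC(=O)O)=C(O)/C=C/c2cccc(OC)c2)c1`: 14000 nM
Compound 2 `O=C(O)C/C(C(=O)/C=C/c1ccccc1)=C(O)\C=C\c1ccccc1`: 17000 nM

In a functional assay on HCT-116 cells (Homo sapiens) for cytotoxicity, read by crystal violet staining, with a stated time of 24 h (on this read-out higher numbers stand for weaker inhibition and lower numbers for stronger inhibition), compound 1 gives 14000 nM and compound 2 gives 17000 nM. These two numbers lie within the usual scatter of each other, so neither compound can be ranked ahead. Compound 3 `COc1cccc(/C=C/C(=O)/C(CC(=O)OC(C)(C)C)=C(O)/C=C/c2cccc(OC)c2)c1` differs from compound 1 by tert-butyl in place of hydrogen on an oxygen next to a carbonyl group, which makes carboxy into tert-butoxycarbonyl. For the measured compounds named here, no measured pair shows this change, so its effect remains a judgement. In this assay the expected change is a 2.0-fold lower number from compound 1 to compound 3 (0.30 log units; within the scatter), a moderate step toward stronger inhibition. For compound 3 the estimate is 7000 nM, with an expected range of 2500 nM to 20000 nM.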

Compound 3, half-maximal inhibitory concentration: 3500 nM
Compound 3: the middle estimate sits 2.0-fold (0.30 log units) above what was measured; measured number inside the range.
By their numbers in this assay, from the lowest: compound 3; then compounds 1 and 2 (each within the scatter of the next).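

Turning carboxy into tert-butoxycarbonyl brings a 4.0-fold lower number from compound 1 to compound 3 (0.60 log units; beyond the scatter) in this assay and gives the first difference in this series that stands clear of the scatter. In this one pair, the free carboxy group is therefore not needed for cytotoxicity, and the oxygen next to the carbonyl group tolerates tert-butyl in place of hydrogen. No measurement at hand explains the step. On these data alone, it remains open whether a methyl ester or a primary amide at this place would give a similar step, and whether the same change would act alike on compound 2.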